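Adding a Chloro Group to an Inactive Benzamide Sulfonamide

The source may report more compounds than this note shows. Statements on the series, on what has been measured and on what is new or still open speak of the compounds shown alone.

Measured compounds:
- Compound 1 `CNC(=O)c1cccc(-c2ccc(OC)c(S(=O)(=O)Nc3cccc(NCCNC(=O)c4ccccc4OC)c3)c2)c1`: 182 nM
- Compound 2 `COc1ccccc1C(=O)NCCNc1cccc(NS(=O)(=O)c2cc(-c3cccc(F)c3)ccc2OC)c1`: > 10000 nM
- Compound 3 `COc1ccc(-c2cccc(C(=O)N(C)C)c2)cc1S(=O)(=O)Nc1cccc(NCCNC(=O)c2ccccc2)c1`: > 10000 nM

All three share a sulfonamide core with a methoxy-substituted biphenyl on one side and a benzamide-capped ethylenediamine chain on the other. In an assay on CHO-K1 cells for agonist activity at Orexin receptor type 2 (Homo sapiens), read by a luciferase reporter (on this read-out higher numbers stand for an effect only at larger amounts of compound and lower numbers for an effect already at smaller amounts), compound 1 gives 182 nM. For compound 2 the result of > 10000 nM is a limit of the assay, not a number. For compound 3 the result of > 10000 nM is likewise only a limit. Compound 3 thus stands at the limit of > 10000 nM in this assay, at which 2 of the 3 values shown sit, and nothing more precise is known about it.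

Compound 4 `COc1ccc(-c2cccc(C(=O)N(C)C)c2)cc1S(=O)(=O)Nc1cccc(NCCNC(=O)c2cccc(Cl)c2)c1` differs from compound 3 by chloro in place of hydrogen on an aromatic carbon. For the measured compounds named here, the only measured step, an at least 54-fold higher number from compound 1 to compound 2 (1.73 log units; beyond the scatter), concerns a change on the biphenyl part of the molecule, not the benzamide cap, so it gives no direct guidance for this new step. With compound 3 already at the limit, the step from compound 3 to compound 4 is expected to be a number no higher from compound 3 to compound 4 (the limit leaves the size open), that is, no move beyond the scatter that can be resolved. Compound 4 is therefore estimated at 10000 nM, within a range from 2000 nM to 30000 nM, most likely reported again as a limit.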

Compound 4, half-maximal effective concentration: 94 nM
For compound 4 the middle estimate is 110-fold (2.03 log units) above the measured one; measured number outside the range, below it.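

In this assay, chloro in place of hydrogen on the benzamide cap, which turns phenyl into 3-chlorophenyl, gives an at least 100-fold lower number from compound 3 to compound 4 (2.02 log units; beyond the scatter). For the compounds shown here, the one earlier step concerned the biphenyl part, so this is the first sign that the cap also matters for activity here: a single added heavy atom, bringing no ring, no hydrogen-bond donor or acceptor and no charge, is enough to turn a compound stuck at the assay's limit into one with a measured number. The full size of this step stays unknown because the result for compound 3 is a limit and not a number: the limit of > 10000 nM in this assay, at which 2 of the 4 values shown sit.

Going by these compounds, whether bromo, a nitrile or an amine in the same place would do what chloro does remains open, and so does whether chloro is needed at this particular place on the ring. The compounds shown also give no reason for the gain, and they do not tell whether the same chloro would rescue compound 2, whose result is likewise only a limit.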